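The source may report more compounds than this note shows. Statements on the series, on what has been measured and on what is new or still open speak of the compounds shown alone.

Compound 3 `O=C(Nc1ccccc1O)C1CCc2ccccc2N1C(=O)c1ccccc1` gives the lowest number of the three in a functional assay on ACHN cells (Homo sapiens) for cytotoxicity, read by sulforhodamine B assay, with a stated time of 72 h (a higher number here means a weaker inhibitor of growth, a lower number a stronger inhibitor of growth), at 4260 nM. Compound 1 `O=C(Nc1ccccc1O)C1CCc2ccccc2N1C(=O)c1ccc(Cl)cc1` gives 19600 nM, and compound 2 `CCCCCCCCC(=O)N1c2ccccc2CCC1C(=O)Nc1ccccc1O` gives 65000 nM. The steps run a 4.6-fold lower number from compound 1 to compound 3 (0.66 log units; beyond the scatter), a 15-fold lower number from compound 2 to compound 3 (1.18 log units; beyond the scatter) and a 3.3-fold higher number from compound 1 to compound 2 (0.52 log units; beyond the scatter). Compound 4 `O=C(Nc1ccccc1O)C1CCc2ccccc2N1` differs from compound 3 by hydrogen in place of benzoyl on a nitrogen on an aromatic ring in a ring. Both steps that reach compound 3 alter the group on this same nitrogen, and each one moved the number beyond the scatter, so a change there is not expected to be neutral. Removing the group outright is expected to raise the number in this assay, by about a 5.9-fold higher number from compound 3 to compound 4 (0.77 log units; beyond the scatter). Compound 4 is therefore estimated at 25000 nM, within a range from 6000 nM to 80000 nM.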

Compound 4, concentration for 50% growth inhibition: 3990 nM
Compound 4: middle estimate off by 6.3-fold (0.80 log units), on the high side, and the stated range ends above it.
By their numbers in this assay, from the lowest: compounds 4 and 3 (each within the scatter of the next); then compound 1; then compound 2.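

The bare nitrogen and the benzoyl group cannot be told apart in this assay, with a 1.1-fold lower number from compound 3 to compound 4 (0.03 log units; within the scatter), so the nitrogen does not need an acyl group to give this level of growth inhibition. Not every acyl group is tolerated equally, however: removal gives a 4.9-fold lower number from compound 1 to compound 4 (0.69 log units; beyond the scatter) for the (4-chlorophenyl)carbonyl group and a 16-fold lower number from compound 2 to compound 4 (1.21 log units; beyond the scatter) for the octylcarbonyl group. Nothing available explains these differences.

As far as these compounds go, it remains open whether a short acetyl group, or a benzyl group without the carbonyl, would stay level with compound 4 or raise the number.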